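Working notes: from compound 3 to compound 4

This account rests on a few compounds, and the source may have more. Where it says the series, first, only, none or still open, it means among the compounds named here.

Compound 1 `Cc1ccc(/N=C2\C(=O)Nc3ccc(S(=O)(=O)N4CCOCC4)cc32)cc1` gives 18900 nM in a functional assay on HCT-116 cells (Homo sapiens) for cytotoxicity, read by sulforhodamine B assay, with a stated time of 24 h (on this read-out higher numbers stand for weaker inhibition and lower numbers for stronger inhibition), and compound 2 `O=C1Nc2ccc(S(=O)(=O)N3CCOCC3)cc2/C1=N/c1ccc(O)cc1` gives 27300 nM there, while compound 3 `O=C1Nc2ccc(S(=O)(=O)N3CCOCC3)cc2/C1=N/Nc1ccccc1` gives 10500 nM on the same read-out. The position of compound 3 rests on two steps: a 1.8-fold lower number from compound 1 to compound 3 (0.26 log units; within the scatter) stays within the scatter, and only a 2.6-fold lower number from compound 2 to compound 3 (0.41 log units; beyond the scatter) goes beyond it.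

Compound 4 `O=C1Nc2ccc(S(=O)(=O)N3CCOCC3)cc2/C1=N/NS(=O)(=O)c1ccccc1` carries phenylsulfonyl in place of phenyl on an amine nitrogen with the shared core unchanged.

The measured steps bear on this only indirectly, as none of them brings in phenylsulfonyl. Among them, a 1.4-fold higher number from compound 1 to compound 2 (0.16 log units; within the scatter) also stays within the scatter, so the one modest step from compound 2 to compound 3 is the largest seen. The expected step is a 1.3-fold higher number from compound 3 to compound 4 (0.12 log units; within the scatter) and so none beyond the scatter, with no direction supported by the data. Compound 4 is expected at 14000 nM (estimated range 5500 nM to 35000 nM).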

Compound 4, half-maximal inhibitory concentration: 13300 nM
Estimate against measurement, compound 4: 1.1-fold (0.02 log units) above, within the range that was stated.
By their numbers in this assay, from the lowest: compounds 3, 4, 1 and 2 (each within the scatter of the next, the first and the last beyond it).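

In this assay, the amine nitrogen tolerates phenylsulfonyl in place of phenyl with no step beyond the scatter (a 1.3-fold higher number from compound 3 to compound 4 (0.10 log units; within the scatter)), so the change brings in two hydrogen-bond acceptors without a clear shift in the number. Against the other two compounds, (phenylsulfonyl)amino gives the same split that anilino gave: the step from the 4-hydroxyphenyl compound goes beyond the scatter (a 2.1-fold lower number from compound 2 to compound 4 (0.31 log units; beyond the scatter)), while the step from the 4-methylphenyl compound stays within it (a 1.4-fold lower number from compound 1 to compound 4 (0.15 log units; within the scatter)). No measurement at hand offers an explanation for any of these steps.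

From the compounds shown here alone, it remains open whether methylsulfonyl or acetyl on the same nitrogen, with no phenyl ring attached, would keep the number in this range. Going by these compounds, the outcome of an amine or a carboxylic acid on the phenyl ring of phenylsulfonyl is also open.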